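Swapping the Aryl Group on the Saturated Ring Carbon

This account rests on a few compounds, and the source may have more. Where it says the series, first, only, none or still open, it means among the compounds named here.

Compound 1 `CC1=C(C(=O)Nc2ccc([N+](=O)[O-])cc2)C(c2ccc(Br)cc2)N=C(SCc2cccc(Cl)c2)N1` was tested in a functional assay on the whole organism (artery, strain albino) with Rattus norvegicus as the target, with a stated time of 30 min, at a dose of 10 mg/kg by the oral route (a lower number here means less inhibition, a higher number more inhibition at the dose given (going by the name of the read-out)), where compound 1 gives 2.6%. Compound 2 `CC1=C(C(=O)Nc2ccc([N+](=O)[O-])cc2)C(c2ccc(Br)cc2)N=C(SCc2ccc(F)cc2)N1` gives 5.2% in the same assay. For the measured compounds named here, the one measured step, a number 2.6 percentage points higher from compound 1 to compound 2 (within the scatter), alters only the group on the saturated chain carbon bound to a sulfur. Compound 1 thus has the smaller of the two numbers seen so far, though its gap to compound 2 lies within the scatter.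

Compound 3 `CC1=C(C(=O)Nc2ccc([N+](=O)[O-])cc2)C(c2cccc([N+](=O)[O-])c2)N=C(SCc2cccc(Cl)c2)N1` differs from compound 1 at a different place: 3-nitrophenyl in place of 4-bromophenyl on a saturated ring carbon. Going by the values given here, no measured step concerns this saturated ring carbon, so the step from compound 1 to compound 2 does not bear directly on the change, and the two numbers in hand are both low. Nothing seen so far points to a move beyond the scatter. Compound 3 is therefore expected to give 4%, within 0% to 15%, an estimated step of a number 1.4 percentage points higher from compound 1 to compound 3 (within the scatter).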

Compound 3, a percentage reported as inhibition, in the whole organism at one dose (the size of the read-out at that dose, not a potency): 4.1%
Compound 3: middle estimate off by 0.1 percentage points, on the low side, and the stated range covers the measured number.
By their numbers in this assay, from the lowest: compounds 1, 3 and 2 (each within the scatter of the next).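

For the compounds shown here, at the saturated ring carbon next to the ring nitrogen, putting 3-nitrophenyl in place of 4-bromophenyl gives a number 1.5 percentage points higher from compound 1 to compound 3 (within the scatter) in this assay, the only measured step at this position. The entering group thus carries hydrogen-bond acceptors and a double bond outside the aromatic ring that the leaving group lacks, and the two compounds still stand within the scatter of each other at this oral dose. No measurement at hand gives a reason for this result.

As far as these compounds go, both groups compared here are substituted phenyl rings, so it stays open what a carboxylic acid, an amine or a short alkyl chain on this saturated ring carbon would give. Also open is whether any group at this carbon reaches a number beyond the scatter of these compounds.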